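Swapping Fluoro for Chloro in Compound 3

This account rests on a few compounds, and the source may have more. Where it says the series, first, only, none or still open, it means among the compounds named here.

In a functional assay on a cell-free system (plasma, Oryctolagus cuniculus) for inhibition, with stated times of 5 min, 1 min and 6 min (a lower number here means a stronger inhibitor, a higher number a weaker inhibitor), compound 1 `CCOC(=O)c1c(C)nc(-c2cccc(C#N)c2)n1C(C)C`, with isopropyl on an aromatic nitrogen of the shared core, gives 9260 nM. Compound 2 `C=CCOn1c(-c2cccc(C#N)c2)nc(C)c1C(=O)OCC`, with allyloxy in that place, gives 5860 nM. The gap between them is a 1.6-fold lower number from compound 1 to compound 2 (0.20 log units; within the scatter), so these two cannot be told apart.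

Compound 3 `CCOC(=O)c1c(C)nc(-c2cccc(C#N)c2)n1OCc1cccc(F)c1`, with (3-fluorobenzyl)oxy on that nitrogen, gives 22400 nM. This is the highest number of the three, which makes it the weakest inhibitor measured so far. The steps leading to it are a 2.4-fold higher number from compound 1 to compound 3 (0.38 log units; beyond the scatter) and a 3.8-fold higher number from compound 2 to compound 3 (0.58 log units; beyond the scatter), and both are modest.

Compound 4 `CCOC(=O)c1c(C)nc(-c2cccc(C#N)c2)n1OCc1cccc(Cl)c1` keeps all of compound 3 except for chloro in place of fluoro on an aromatic carbon, meta to a large group: chloro in place of fluoro on an aromatic carbon. For the measured compounds named here, no measured pair makes this swap, so there is no direct evidence for it. The nearest guide is compound 3 itself, where replacing the whole vinyl end with 3-fluorophenyl gave only a 3.8-fold higher number from compound 2 to compound 3 (0.58 log units; beyond the scatter). A change confined to the fluoro is therefore expected to be smaller still, with no shift beyond the scatter. The expected step is a 1.1-fold lower number from compound 3 to compound 4 (0.05 log units; within the scatter). For compound 4 the estimated value is 20000 nM, with an expected range from 9000 nM to 45000 nM.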

Compound 4, half-maximal inhibitory concentration: 19400 nM
Compound 4: middle estimate off by 1.0-fold (0.01 log units), on the high side, within the range that was stated.
By their numbers in this assay, from the lowest: compounds 2 and 1 (each within the scatter of the next); then compounds 4 and 3 (each within the scatter of the next).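

In this assay, for the compounds shown here, this is the first direct test of the aromatic carbon meta to a large group, and chloro in place of fluoro makes no change that can be read: a 1.2-fold lower number from compound 3 to compound 4 (0.06 log units; within the scatter). The chloro compound also keeps the same standing against the two compounds without a benzyl-type group, with a 3.3-fold higher number from compound 2 to compound 4 (0.52 log units; beyond the scatter) and a 2.1-fold higher number from compound 1 to compound 4 (0.32 log units; beyond the scatter); both steps lie beyond the scatter but are modest, as the matching steps to compound 3 were. So, among these compounds, the choice between the two halogens at this carbon matters less than the choice of group on the aromatic nitrogen, and no measurement at hand offers an explanation for either observation.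

From the compounds shown here alone, what remains open is whether this carbon tolerates any group or only these two halogens, since a plain hydrogen, a methoxy, a trifluoromethyl or an amine there could give quite different numbers. The ethyl ester and the nitrile stay the same throughout, so the effect of changing either one, for instance the ester to a carboxylic acid, is also unknown.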